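Third methoxy on the pendant aryl of compound 2

The compounds below may be only part of what the source reports. "The series", "measured", "known", "first", "only" and "open" are said of these compounds alone.

Compound 2 `COc1ccc(-c2cc(-c3cc(C(C)C)c(O)cc3C)[nH]c(=O)c2C#N)c(OC)c1` gives 58% in a functional assay for inhibition, tested at 100 ug/mL (on this read-out lower numbers stand for a weaker effect and higher numbers for a stronger effect at the one concentration tested), the highest of the three numbers measured: compound 3 `COc1cc(-c2cc(-c3cc(C(C)C)c(O)cc3C)[nH]c(=O)c2C#N)ccc1O` stands nearest with 44%, compound 1 `Cc1cc(O)c(C(C)C)cc1-c1cc(-c2ccccc2)c(C#N)c(=O)[nH]1` furthest with 41%. Compound 4 `COc1cc(OC)c(-c2cc(-c3cc(C(C)C)c(O)cc3C)[nH]c(=O)c2C#N)c(OC)c1` differs from compound 2 by methoxy in place of hydrogen on an aromatic carbon, a methoxy entering meta to two methoxy groups on the same six-membered ring. Among the compounds with values here, the steps bearing on this are a number 17 percentage points higher from compound 1 to compound 2 (beyond the scatter) and a number 14 percentage points lower from compound 2 to compound 3 (beyond the scatter); methoxy groups on that ring go with the higher number here, though no step adds a single methoxy. A small rise or none beyond the scatter is expected, a number 4 percentage points higher from compound 2 to compound 4 (within the scatter). Compound 4 is estimated at 62%, between 46% and 78%.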

Compound 4, a percentage reported as inhibition, at one concentration (the size of the read-out at that concentration, not a potency): 82.5%
For compound 4 the middle estimate is 20.5 percentage points below the measured one, and the stated range ends below it.
By their numbers in this assay, from the lowest: compounds 1 and 3 (each within the scatter of the next); then compound 2; then compound 4.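

In this assay, methoxy in place of hydrogen, ortho to a large group and meta to two methoxy groups, goes with a number 24.5 percentage points higher from compound 2 to compound 4 (beyond the scatter). Earlier steps exchanged whole substitution patterns on the pendant aryl; this one reads a single added methoxy, and this position takes it with a gain beyond the scatter. Nothing on hand accounts for the size of this rise.

As far as these compounds go, whether the gain belongs to this position alone or needs the other two methoxy groups remains open. Also open, from the compounds shown here alone, is how an amine, a fluorine atom or a longer alkoxy chain would read at this position.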